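The compounds below may be only part of what the source reports. "The series", "measured", "known", "first", "only" and "open" are said of these compounds alone.

Measured compounds:
- Compound 1, `Cn1nc(-c2ccccc2)c2c1OC(N)=C(C#N)C2c1ccc(F)cc1`, in a functional assay on NCI-H2122 cells (Homo sapiens) for inhibition, read by microscopy, with a stated time of 10 days (on this read-out lower numbers stand for stronger inhibition and higher numbers for weaker inhibition), compound 1 gives > 10000 nM, which is a limit of the assay.
- Compound 2, `Cn1nc(-c2ccccc2)c2c1OC(N)=C(C#N)C2c1cccnc1`, in this assay compound 2 gives > 10000 nM, again a limit.

Compound 2 therefore stands at the limit, and the limit of > 10000 nM in this assay, at which 2 of the 2 values shown sit, describes everything measured so far in this assay. Among the measured compounds shown here, the one step measured, a step that the two limits leave unreadable from compound 1 to compound 2, cannot be read for size or direction.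

Compound 3, `Cn1nc(-c2ccccc2)c2c1OC(N)=C(C#N)C2c1cccc(Br)n1`, differs from compound 2 in this way: 6-bromopyridin-2-yl in place of pyridin-3-yl on a saturated ring carbon. No measured step bears on this change, since the only step shown is unreadable. Compound 3 is therefore expected to sit near the limit as well, so the step of a number no higher from compound 2 to compound 3 (the limit leaves the size open) is estimated as none beyond the scatter. The expected value for compound 3 in this assay is 10000 nM, within a range of 2500 nM to 40000 nM.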

Compound 3, half-maximal inhibitory concentration: 1700 nM
Beside the measured number, compound 3's estimate is 5.9-fold (0.77 log units) above it; the whole stated range lies above it.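

The saturated ring carbon next to the ring atom that bears a cyano group can carry a readable inhibition in this assay: 6-bromopyridin-2-yl in place of pyridin-3-yl gives an at least 5.8-fold lower number from compound 2 to compound 3 (0.76 log units; beyond the scatter), and in place of 4-fluorophenyl it gives an at least 5.8-fold lower number from compound 1 to compound 3 (0.76 log units; beyond the scatter). As far as these compounds go, the true size of both steps stays open, as each starts from a limit, so each marks only a minimum. Of the compounds shown, compound 3 alone has a number rather than a limit, and the group on this carbon is the only thing that sets it apart: the limit of > 10000 nM in this assay, at which 2 of the 3 values shown sit.

The change brings in a bromine atom and alters the pyridine attachment together, so the shown compounds do not separate the two. Still open, from the compounds shown here alone, is whether an unsubstituted pyridin-2-yl, or a chlorine, methyl or amine in place of the bromine, would keep this inhibition.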